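Indolylmethyl to benzyl on a piperidine-linked oxazolidinone

The source may report more compounds than this note shows. Statements on the series, on what has been measured and on what is new or still open speak of the compounds shown alone.

Three compounds share one core and were tested in an in vitro functional assay on RBL cells for antagonist activity at C-C chemokine receptor type 8 (Homo sapiens), read by FLIPR and calcium flux; on this read-out higher numbers stand for weaker inhibition and lower numbers for stronger inhibition. Compound 1 `COc1ccc2nccc(C3CN(CC4CCCN(Cc5cc6ccccc6[nH]5)C4)C(=O)O3)c2c1` gives < 50200 nM, which is a limit of the assay and not a number. Compound 2 `COc1ccc2nccc(C3CN(C4CCCCN(Cc5cc6ccccc6[nH]5)C4)C(=O)O3)c2c1` likewise gives < 50200 nM, again a limit. Compound 3 `COc1ccc2nccc(C3CN(C4CCN(Cc5c[nH]c6ccccc56)CC4)C(=O)O3)c2c1` gives < 50200 nM, also a limit, so all three values shown sit at the limit of < 50200 nM in this assay, at which 3 of the 3 values shown sit, and no ranking among them can be read. Compound 4 `COc1ccc2nccc(C3CN(C4CCN(Cc5ccccc5)CC4)C(=O)O3)c2c1` differs from compound 3 by phenyl in place of 1H-indol-3-yl on a saturated chain carbon bound to an amine nitrogen in a ring. Among the compounds with values here, with no measured step to lean on, no step beyond the usual scatter is expected in this assay, and a limit again is quite possible. Compound 4 is expected at 8000 nM with a range from 800 nM to 50000 nM. The expected step that the limit leaves unreadable from compound 3 to compound 4 is thus essentially flat.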

Compound 4, half-maximal inhibitory concentration: 12600 nM
For compound 4 the middle estimate is 1.6-fold (0.20 log units) below the measured one; the measured number falls inside the stated range.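

In this assay, within the data shown here, no step from compound 3 to compound 4 can be read, since compound 3 stands at a limit and not at a number: the limit of < 50200 nM in this assay, at which 3 of the 4 values shown sit.

The compounds shown leave open how (1H-indol-3-yl)methyl and benzyl compare on this core.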